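Replacing the 4-bromophenyl group of compound 3

The compounds below may be only part of what the source reports. "The series", "measured", "known", "first", "only" and "open" are said of these compounds alone.

Values measured in a physicochemical assay for solubility, read by HPLC, in phosphate buffer, with a stated time of 16 h, at pH 6.8; a lower number here means a less soluble compound, a higher number a more soluble compound:
- Compound 1 `C[C@@H](NC(=O)Cn1nnc2ccccc2c1=O)c1ccccc1`: 1200 nM
- Compound 2 `COc1ccc([C@H](C)NC(=O)Cn2nnc3ccccc3c2=O)cc1`: 15000 nM
- Compound 3 `C[C@H](NC(=O)Cn1nnc2ccccc2c1=O)c1ccc(Br)cc1`: 900 nM

Compound 3, at 900 nM, lies within the scatter of compound 1, and both values lie well under that of compound 2. Among the measured compounds shown here, the only measured step between compounds that differ in one place is a 17-fold lower number from compound 2 to compound 3 (1.22 log units; beyond the scatter), with bromo in place of methoxy on an aromatic carbon.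

The next structure is compound 4 `Cc1ccc([C@H](C)NC(=O)Cn2nnc3ccccc3c2=O)c(F)c1`, which differs from compound 3 as follows: 2-fluoro-4-methylphenyl in place of 4-bromophenyl on a saturated chain carbon bound to an amide-type nitrogen and a saturated chain carbon. The measured step bears on this change only loosely. For the measured compounds named here, it shows that an exchange on the aryl group can move the number a long way in this assay, but 2-fluoro-4-methylphenyl appears in no measured compound. No step beyond the scatter is therefore expected, and any lean is tentatively towards a higher number. The expected step is a 1.7-fold higher number from compound 3 to compound 4 (0.22 log units; within the scatter). Compound 4 is estimated at 1500 nM, with an expected range from 400 nM to 6000 nM.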

Compound 4, solubility: 4500 nM
Compound 4: the middle estimate sits 3.0-fold (0.48 log units) below what was measured, and the stated range covers the measured number.
By their numbers in this assay, from the lowest: compounds 3 and 1 (each within the scatter of the next); then compound 4; then compound 2.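

In this assay, the exchange of 4-bromophenyl for 2-fluoro-4-methylphenyl gives a 5.0-fold higher number from compound 3 to compound 4 (0.70 log units; beyond the scatter), so this position responds beyond the scatter even to a change between two groups that each count no hydrogen-bond donors or acceptors. Against 4-methoxyphenyl, the same group gives a 3.3-fold lower number from compound 2 to compound 4 (0.52 log units; beyond the scatter), which places compound 4 at an intermediate level, with its own step to each of the two para-free named neighbours beyond the scatter. No measurement on hand accounts for either step.

Whether the fluoro or the methyl group carries the step stays open, as neither appears alone in the compounds shown. Also open, going by these compounds, is how an aryl group bearing an amine or a carboxylic acid would read in this assay.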